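Naphthalen-1-yl in Place of the Formylphenyl Arm

A few compounds are considered here, and "the series" means these few. Any claim that something is new, unique, unknown or untested is made for them only; others in the source may bear on it.

Compound 3, `O=Cc1ccc(-c2cn3ccnc3c(-c3ccc4ncn(C5CCCCC5)c4c3)n2)cc1`, gives 92.6% in a functional assay on HCT-116 cells (Homo sapiens) for inhibition, read by sulforhodamine B assay, with a stated time of 48 h, tested at 10 uM (on this read-out lower numbers stand for less inhibition and higher numbers for more inhibition at the one concentration tested (going by the name of the read-out)), the highest of the three measured numbers. Compound 2, `COc1ccc(-c2cn3ccnc3c(-c3ccc4ncn(C5CCCCC5)c4c3)n2)cc1`, gives 91.3%, and a number 1.3 percentage points higher from compound 2 to compound 3 (within the scatter). Compound 1, `c1ccc(-c2cn3ccnc3c(-c3ccc4ncn(C5CCCCC5)c4c3)n2)cc1`, gives 59.5%, and a number 33.1 percentage points higher from compound 1 to compound 3 (beyond the scatter). The unmeasured compound 4, `c1ccc2c(-c3cn4ccnc4c(-c4ccc5ncn(C6CCCCC6)c5c4)n3)cccc2c1`, differs from compound 3 in one place: naphthalen-1-yl in place of 4-formylphenyl on an aromatic carbon. Among the compounds with values here, only that last step bears on the change: the formyl that leaves had brought a large gain, so its loss alone points to a drop of similar size. Within the data shown here, no measured step shows what a second fused aromatic ring adds, so the outcome is uncertain. Compound 4 is therefore expected to fall between the two measured levels, with a number 22.6 percentage points lower from compound 3 to compound 4 (beyond the scatter) as a moderate drop, estimated at 70% in the range 45% to 92%.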

Compound 4, a percentage reported as inhibition, at one concentration (the size of the read-out at that concentration, not a potency): 17.9%
Estimate against measurement, compound 4: 52.1 percentage points above; the whole stated range lies above it.
By their numbers in this assay, from the lowest: compound 4; then compound 1; then compounds 2 and 3 (each within the scatter of the next).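

In this assay, this position does not reward every larger aromatic arm: naphthalen-1-yl gives a number 74.7 percentage points lower from compound 3 to compound 4 (beyond the scatter) and a number 73.4 percentage points lower from compound 2 to compound 4 (beyond the scatter) as well. It also falls short of the unsubstituted phenyl arm, with a number 41.6 percentage points lower from compound 1 to compound 4 (beyond the scatter) showing that the second fused ring goes with a lower number, not merely with no gain. No available evidence accounts for this drop. Still open, on these data alone, is how an amine or a carboxylic acid on the phenyl arm would read, and whether naphthalen-2-yl, joined through a different ring carbon, would fall as low as compound 4.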